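The compounds below may be only part of what the source reports. "The series", "measured", "known", "first", "only" and "open" are said of these compounds alone.

Compound 1 `CCCCCCNC(=O)CCC(NS(=O)(=O)c1cc(Cl)ccc1Cl)C(=O)NCCCCCC` and compound 2 `CCCCCCNC(=O)CCC(NS(=O)(=O)c1cc(C)ccc1Cl)C(=O)NCCCCCC` share one core and differ only in the aryl group on the sulfonyl sulfur. In a functional assay on IMR-32 cells (Homo sapiens) for cytotoxicity, read by MTT assay, tested at 60 ug/mL (a lower number here means less inhibition, a higher number more inhibition at the concentration tested (going by the name of the read-out)), compound 1 gives 12.4%, and compound 2 gives 11.3%; the step of a number 1.1 percentage points lower from compound 1 to compound 2 (within the scatter) leaves the two within the scatter of each other, so compound 2 stands on the same footing as compound 1. Compound 3 `CCCCCCNC(=O)CCC(NS(=O)(=O)c1ccc(C)cc1C)C(=O)NCCCCCC` carries a further change at that position: 2,4-dimethylphenyl in place of 2-chloro-5-methylphenyl on a sulfonyl sulfur. Among the compounds with values here, only one measured step, from compound 1 to compound 2, bears on such an aryl swap, and it was small, so no step beyond the scatter is expected in this assay, a number 0.7 percentage points higher from compound 2 to compound 3 (within the scatter). Compound 3 is therefore expected to give 12%, between 4% and 22%.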

Compound 3, a percentage reported as inhibition, at one concentration (the size of the read-out at that concentration, not a potency): 66%
Compound 3: the middle estimate sits 54 percentage points below what was measured; measured number outside the range, above it.
By their numbers in this assay, from the lowest: compounds 2 and 1 (each within the scatter of the next); then compound 3.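

In this assay, the aryl group on the sulfonyl sulfur proves able to move the number a long way: 2,4-dimethylphenyl gives a number 54.7 percentage points higher from compound 2 to compound 3 (beyond the scatter), and against 2,5-dichlorophenyl it gives a number 53.6 percentage points higher from compound 1 to compound 3 (beyond the scatter). The methyl group of compound 2 did not bring such a rise, so a methyl as such is not enough. No measurement offered here explains the jump.

Compound 3 both lacks chlorine and places its methyl groups differently, and these two changes remain unseparated. A 2,5-dimethylphenyl or 4-methylphenyl group would pull them apart.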